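The source may report more compounds than this note shows. Statements on the series, on what has been measured and on what is new or still open speak of the compounds shown alone.

Measured so far in an in vitro ADME assay on microsomes from liver (Homo sapiens) for metabolic stability; on this read-out lower numbers stand for slow clearance and higher numbers for fast clearance:

- compound 1 `c1ccc(C2Cc3nccn3C2)cc1`: 15 mL.min-1.g-1; < 7 mL.min-1.g-1 (2 entries)
- compound 2 `Clc1ccccc1C1Cc2nccn2C1`: 18 mL.min-1.g-1
- compound 3 `Fc1ccccc1C1Cc2nccn2C1`: "not determined" (no result reported)

Compound 3 stands without a number in this assay, and one further entry for it also gives none, so its own place in the series is open. Compound 1 is the anchor of the series, and its repeated entries the several entries of compound 1 in this assay, 15 mL.min-1.g-1; < 7 mL.min-1.g-1 (2 entries) show how the read-out spreads between a number and a limit for the same compound. Compound 2 gives a number in this assay that sits within the scatter of the numbered entry of compound 1.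

Compound 4 `COCc1ccccc1C1Cc2nccn2C1` differs from compound 3 by methoxymethyl in place of fluoro on an aromatic carbon. Among the compounds with values here, no measured step is available between them. Against the two numbers known for the series, a step in this assay of modest size toward faster clearance is expected for compound 4, though a result within the scatter of compound 2 cannot be excluded. Compound 4 is estimated at 25 mL.min-1.g-1, with an expected range from 8 mL.min-1.g-1 to 70 mL.min-1.g-1.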

Compound 4, intrinsic clearance in microsomes: < 7 mL.min-1.g-1
Compound 4: no number, only a limit; the forecaster's own chance of this, stated with the estimate: 15%; at least 3.5-fold (0.55 log units) between middle value and limit.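

Within the data shown here, with methoxymethyl in place of chloro on this aromatic carbon, this assay shows an at least 2.5-fold lower number from compound 2 to compound 4 (0.41 log units; beyond the scatter), the only step so far. The value of compound 4 is a limit, not a number. Compound 1, with neither group at this position, has a limit among its entries, so reaching the limit is not specific to methoxymethyl: the several entries of compound 1 in this assay, 15 mL.min-1.g-1; < 7 mL.min-1.g-1 (2 entries)

The compounds shown leave open whether the lower number goes with the oxygen of methoxymethyl or with a chain as such, and an ethyl group or an aminomethyl group on the same aromatic carbon would help to separate these readings. Where compound 3, with fluoro at this position, stands relative to compound 2 and compound 4 also remains open.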